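The compounds below may be only part of what the source reports. "The series", "measured", "known", "first", "only" and "open" are said of these compounds alone.

In a functional assay on HMEC-1 cells (Homo sapiens) for antiproliferative activity, read by cell counting, with a stated time of 4 days (a higher number here means a weaker inhibitor, a lower number a stronger inhibitor), two compounds on a shared core have been measured so far. Compound 1 `COc1ccc(Oc2ccccc2NC(C)=C2C(=O)CC(c3ccccc3)CC2=O)cc1` gives 83 nM, and compound 2 `CC(Nc1ccccc1Oc1ccc(C(C)O)cc1)=C1C(=O)CC(c2ccccc2)CC1=O` gives 140 nM. Within the data shown here, the only measured step is a 1.7-fold higher number from compound 1 to compound 2 (0.23 log units; within the scatter). Compound 2 therefore stands level with compound 1 on these numbers, and the pair sets no order.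

Next in the series is compound 3 `CC(Nc1ccccc1Oc1ccc(N)cc1)=C1C(=O)CC(c2ccccc2)CC1=O`, with amino in place of 1-hydroxyethyl on an aromatic carbon, para to a large group: amino in place of 1-hydroxyethyl on an aromatic carbon. Among the measured compounds shown here, no measured compound carries amino at this place, so the data give no direct reading of that group. For the measured compounds named here, the one step bearing on the change is the replacement of methoxy by 1-hydroxyethyl on the same aromatic carbon, which amounted to a 1.7-fold higher number from compound 1 to compound 2 (0.23 log units; within the scatter). That single small step is thin evidence, but it gives no reason to expect a large shift in this assay, and no direction can be argued from it. The estimated step is a 1.3-fold lower number from compound 2 to compound 3 (0.10 log units; within the scatter), with nothing expected beyond the scatter. For compound 3 the expected value is 110 nM, with an estimated range of 40 nM to 300 nM.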

Compound 3, half-maximal inhibitory concentration: 47 nM
For compound 3 the middle estimate is 2.3-fold (0.37 log units) above the measured one; measured number inside the range.
By their numbers in this assay, from the lowest: compounds 3, 1 and 2 (each within the scatter of the next, the first and the last beyond it).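

In this assay, the aromatic carbon para to a large group now gives a step beyond the scatter, which the earlier pair did not: amino in place of 1-hydroxyethyl gives a 3.0-fold lower number from compound 2 to compound 3 (0.47 log units; beyond the scatter). Amino in place of methoxy on the same carbon gives a 1.8-fold lower number from compound 1 to compound 3 (0.25 log units; within the scatter), so compound 1 and compound 3 stand level, and the only separation in the set lies between compound 2 and compound 3. Both groups exchanged in the step beyond the scatter count one hydrogen-bond donor and one hydrogen-bond acceptor, and no measurement offered here bears on what lies behind the difference between them.

Still open, on these data alone, is whether that step belongs to amino itself or to the removal of 1-hydroxyethyl; a hydroxyl or a plain methyl at this carbon, and an acetamide or a dimethylamino group in place of amino, would separate these readings. As far as these compounds go, all three compounds also share the rest of the core, so whether the step holds when another part of the core changes remains unknown.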